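Swapping Cyclopropyl for Oxan-4-yl: Expected Microsomal Clearance

The source may hold more compounds than are shown below. What is called first, only, known or untested is meant among the compounds shown, and "the series" means these compounds.

Measured so far:
compound 1 `NC1=N[C@@]2(CO1)c1cc(NC(=O)c3ccc(Cl)cn3)ccc1Oc1cnc(Cl)cc12`: 37 mL.min-1.g-1
compound 2 `NC1=N[C@@]2(CO1)c1cc(NC(=O)c3ccc(Cl)cn3)ccc1Oc1cnc(C3CC3)cc12`: < 14 mL.min-1.g-1

In an ADME assay on microsomes from liver (Homo sapiens) for metabolic stability, read by LC-MS, using NADPH, with a stated time of 30 min, tested at 1 uM (on this read-out lower numbers stand for slow clearance and higher numbers for fast clearance), compound 1 gives 37 mL.min-1.g-1. Compound 2 reaches only a limit of the assay, < 14 mL.min-1.g-1, which is the limit of < 14 mL.min-1.g-1 in this assay, at which 1 of the 2 values shown sits. The step of an at least 2.6-fold lower number from compound 1 to compound 2 (0.42 log units; beyond the scatter) runs toward slow clearance. Compound 3 `NC1=N[C@@]2(CO1)c1cc(NC(=O)c3ccc(Cl)cn3)ccc1Oc1cnc(C3CCOCC3)cc12` differs from compound 2 by oxan-4-yl in place of cyclopropyl on an aromatic carbon. Within the data shown here, no measured step compares these two groups, so the only guide is that compound 2 already sits at the limit. Compound 3 is therefore expected to stay near that limit, a step that the limit leaves unreadable from compound 2 to compound 3 not expected to pass beyond the scatter. Compound 3 is estimated at 12 mL.min-1.g-1, between 5 mL.min-1.g-1 and 30 mL.min-1.g-1.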

Compound 3, intrinsic clearance in microsomes: 80 mL.min-1.g-1
Beside the measured number, compound 3's estimate is 6.7-fold (0.82 log units) below it; the measured number lies above the stated range.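

Changing the group on this aromatic carbon, next to the ring nitrogen, can raise clearance as well as lower it in this assay: oxan-4-yl in place of cyclopropyl brings an at least 5.7-fold higher number from compound 2 to compound 3 (0.75 log units; beyond the scatter). Compound 2 stands at a limit of the assay, not at a number: the limit of < 14 mL.min-1.g-1 in this assay, at which 1 of the 3 values shown sits. Oxan-4-yl in place of chloro also gives a 2.2-fold higher number from compound 1 to compound 3 (0.33 log units; beyond the scatter), so the drop seen with cyclopropyl does not carry over to this other ring.

As far as these compounds go, whether the rise follows the ring oxygen or the larger ring stays open. A cyclohexyl group, an all-carbon six-membered ring, would separate the two.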